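From difluorophenyl to hydroxypyridinyl on the shared core

A few compounds are considered here, and "the series" means these few. Any claim that something is new, unique, unknown or untested is made for them only; others in the source may bear on it.

Of the compounds shown here, three have been measured for antagonist activity. Compound 1 `CCC(c1ccccc1)c1nc(-c2ccc(Cl)cc2)c(CC(=O)O)s1` reaches only the limit of > 100000 nM in an in vitro functional assay on HEK285-7 cells for antagonist activity at prostaglandin D2 receptor 2 (Homo sapiens), read by BRET and beta-arrestin recruitment; on this read-out higher numbers stand for weaker inhibition and lower numbers for stronger inhibition. For the measured compounds named here, compound 2 `O=C(O)Cc1sc(C(c2ccccc2)c2ccc(Cl)cc2)nc1-c1ccc(Cl)cc1` gives 75 nM, and the step of an at least 1300-fold lower number from compound 1 to compound 2 (3.12 log units; beyond the scatter) is the only measured change in this set. Compound 3 `O=C(O)Cc1sc(C(c2ccc(F)cc2)c2ccc(F)cc2)nc1-c1cc(F)cc(F)c1` gives 340 nM, the highest of the two numbers, and its gap from compound 2 lies beyond the scatter. Compound 4 `O=C(O)Cc1sc(C(c2ccc(F)cc2)c2ccc(F)cc2)nc1-c1ccnc(O)c1` carries 2-hydroxypyridin-4-yl in place of 3,5-difluorophenyl on an aromatic carbon. Going by the values given here, no measured step touches this aromatic carbon; the one known step concerns the saturated chain carbon instead, so it offers no guide to the direction here. The chemist therefore expects for compound 4 a step of a 1.8-fold higher number from compound 3 to compound 4 (0.25 log units; within the scatter), modest and close to the scatter. Compound 4 is estimated at 600 nM, within the range 150 nM to 3000 nM.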

Compound 4, half-maximal inhibitory concentration: 890 nM
The estimate for compound 4 lay 1.5-fold (0.17 log units) below the measured number; low and high end bracket the measured number.
By their numbers in this assay, from the lowest: compound 2; then compound 3; then compound 4. At a limit, above all of these: compound 1.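

For the compounds shown here, exchanging 3,5-difluorophenyl for 2-hydroxypyridin-4-yl gives a 2.6-fold higher number from compound 3 to compound 4 (0.42 log units; beyond the scatter), the first measured change on this aromatic carbon next to the ring nitrogen. The step is modest, so this position accepts a six-membered aromatic ring with a hetero atom, and inhibition weakens without being lost. Nothing measured on these compounds accounts for the size of this step.

The compounds shown leave open whether the ring nitrogen or the hydroxy group sets this step. They also leave open how an unsubstituted pyridinyl or a methoxypyridinyl would compare at this position.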